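The compounds below may be only part of what the source reports. "The series", "measured", "known", "first", "only" and "open" are said of these compounds alone.

Measured compounds:
compound 1, `OC[C@H]1O[C@@H](n2cnc3c(NCc4cccc(F)c4)ncnc32)[C@H](O)[C@@H]1O`: > 166000 nM
compound 2, `Cc1ccc(CNc2ncnc3c2ncn3[C@@H]2O[C@H](CO)[C@@H](O)[C@H]2O)cc1`: "not determined" (no result reported)

Compound 1 gives only a limit in a functional assay on G-361 cells (Homo sapiens) for antiproliferative activity, with a stated time of 72 h (on this read-out lower numbers stand for stronger inhibition and higher numbers for weaker inhibition), namely > 166000 nM; this is a limit of the assay and not a number (the limit of > 166000 nM in this assay, at which 1 of the 2 values shown sits). For compound 2, this assay reports "not determined" (no result reported). Compound 2 therefore stands nowhere on the numbers shown: it has no value of its own, and the one further value in the series is a limit.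

Compound 3, `OC[C@H]1O[C@@H](n2cnc3c(NCc4ccc(F)cc4Cl)ncnc32)[C@H](O)[C@@H]1O`, is to be measured in this assay. It differs from compound 2 in one place: 2-chloro-4-fluorophenyl in place of 4-methylphenyl on a saturated chain carbon bound to a nitrogen on an aromatic ring. Going by the values given here, no step between measured compounds exists in this assay, so nothing measured anchors the size of the change from compound 2 to compound 3; with only the limit of compound 1 in view, no direction beyond the scatter can be set, and the expectation is that compound 3 also sits near or at the limit. Compound 3 is estimated to give 150000 nM in this assay, expected to fall between 30000 nM and 400000 nM, with a strong chance that only a limit is reported.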

Compound 3, half-maximal inhibitory concentration: > 166000 nM
Compound 3: only a limit was reported; the forecaster's own chance of this, stated with the estimate: 70%; middle value at least 1.1-fold (0.04 log units) from the limit.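

In this assay compound 3 gives > 166000 nM, which is a limit and not a number. Compound 1 also gives only a limit, so the step between compound 1 and compound 3 cannot be read. The compounds shown leave open how the different benzyl groups on the shared core rank in this assay.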